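A few compounds are considered here, and "the series" means these few. Any claim that something is new, unique, unknown or untested is made for them only; others in the source may bear on it.

Compound 3 `FC(F)(F)c1ccc(Cl)nc1N1CCN(Cc2nc3ccccc3[nH]2)CC1` gives 12600 nM in an assay on CHO cells with metabotropic glutamate receptor 2 (Homo sapiens) as the target, read by FLIPR (a lower number here means that less compound is needed, a higher number that more compound is needed for the effect), the highest of the three numbers recorded. Compound 2 `CCn1c(CN2CCN(c3ncc(Cl)cn3)CC2)nc2ccccc21` gives 158 nM in this assay, and compound 1 `Cn1c(CN2CCN(c3ncc(C(F)(F)F)cc3Cl)CC2)nc2ccccc21` gives 79.4 nM, both separated from compound 3 by steps well beyond the scatter. Compound 4 `COCCn1c(CN2CCN(c3nc(Cl)ccc3C(F)(F)F)CC2)nc2ccccc21` differs from compound 3 by 2-methoxyethyl in place of hydrogen on an aromatic nitrogen. Among the compounds with values here, no directly comparable step between measured compounds exists, yet compounds 1 and 2, which also carry a group on that aromatic nitrogen, sit far below compound 3 in this assay. The step of a 42-fold lower number from compound 3 to compound 4 (1.62 log units; beyond the scatter) is therefore expected to be large, in the direction of less compound being needed. Compound 4 is expected to give about 300 nM in this assay, within a range from 80 nM to 1200 nM.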

Compound 4, half-maximal effective concentration: 158 nM
Compound 4: middle estimate off by 1.9-fold (0.28 log units), on the high side, within the range that was stated.
By their numbers in this assay, from the lowest: compounds 1, 2 and 4 (each within the scatter of the next); then compound 3.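

In this assay, within the data shown here, the pair gives the first direct reading of this position: 2-methoxyethyl in place of hydrogen on the aromatic nitrogen, with the rest of the structure unchanged, brings an 80-fold lower number from compound 3 to compound 4 (1.90 log units; beyond the scatter). Compounds 1 and 2 differ from compound 3 in more than one place, so they could not isolate this change. Nothing measured here bears on why the step is so large. From the compounds shown here alone, it remains open whether the oxygen of the chain matters, since a plain propyl chain on the same core would be needed to tell. Going by these compounds, how a chain ending in an amine or a carboxylic acid would compare also remains open.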